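Swapping a Pyrrolyl Group for a Bromofuranyl Group

A few compounds are considered here, and "the series" means these few. Any claim that something is new, unique, unknown or untested is made for them only; others in the source may bear on it.

Of the compounds shown here, three have been measured in a functional assay on HT-29 cells (Homo sapiens) for inhibition, read by MTT assay, with a stated time of 72 h; a lower number here means a stronger inhibitor of growth, a higher number a weaker inhibitor of growth. Compound 1 `N#C/C(=C\c1ccc(Cl)cc1)C(=O)c1ccc[nH]1` gives 36000 nM in this assay, and compound 2 `N#C/C(=C\c1c(F)c(F)c(F)c(F)c1F)C(=O)c1c[nH]c2ccccc12` gives 18000 nM. Compound 3 `COc1ccc(CNC(=O)/C(C#N)=C/c2ccc[nH]2)cc1` gives only a limit in this assay, > 50000 nM, which means no number was obtained for it. For the measured compounds named here, compound 3 therefore sits at the limit of > 50000 nM in this assay, at which 1 of the 3 values shown sits, the one compound whose growth inhibition could not be pinned to a value.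

Compound 4 `COc1ccc(CNC(=O)/C(C#N)=C/c2ccc(Br)o2)cc1` is built from compound 3 by one change: 5-bromofuran-2-yl in place of 1H-pyrrol-2-yl on a double-bonded chain carbon bound to a double-bonded chain carbon. Going by the values given here, no pair of measured compounds shares this change, so no measured step shows how large a move it brings. The step of an at least 1.6-fold lower number from compound 3 to compound 4 (0.22 log units; that floor lies within the scatter) is expected to be small, leaning toward somewhat stronger growth inhibition but not clearly beyond the usual scatter. Compound 4 is expected to give about 30000 nM in this assay, with a likely range from 8000 nM to 100000 nM, and a real chance that it is also reported only as a limit.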

Compound 4, concentration for 50% growth inhibition: 10000 nM
The estimate for compound 4 lay 3.0-fold (0.48 log units) above the measured number; low and high end bracket the measured number.
By their numbers in this assay, from the lowest: compounds 4, 2 and 1 (each within the scatter of the next, the first and the last beyond it). At a limit, above all of these: compound 3.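

In this assay, 5-bromofuran-2-yl in place of 1H-pyrrol-2-yl on a double-bonded chain carbon bound to a double-bonded chain carbon gives an at least 5.0-fold lower number from compound 3 to compound 4 (0.69 log units; beyond the scatter). For the compounds shown here, this is the first measured sign that this position can move growth inhibition, and compound 4, at 10000 nM, has a real number where its partner has none. For compound 3 the assay gives a limit and not a number, so the step is only a floor: the limit of > 50000 nM in this assay, at which 1 of the 4 values shown sits.

The change swaps the ring's hetero atom and brings in bromine at once, and the compounds shown do not tell which of the two carries the step. A plain furan-2-yl group or a 5-methylfuran-2-yl group at the same place would be needed to separate them.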